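Adding a hydroxymethyl branch beside the benzylic methyl

This account rests on a few compounds, and the source may have more. Where it says the series, first, only, none or still open, it means among the compounds named here.

Measured compounds in an assay on CHO cells for agonist activity at 5-hydroxytryptamine receptor 1D (Homo sapiens), read by GTPgammaS binding; on this read-out higher numbers stand for an effect only at larger amounts of compound and lower numbers for an effect already at smaller amounts:
- compound 1 `CN(Cc1cccs1)C1CCN(CCCc2c[nH]c3ccc(-n4cnnc4)cc23)CC1`: 3.5 nM
- compound 2 `c1ccc(CNC2CCN(CCCc3c[nH]c4ccc(-n5cnnc5)cc34)CC2)cc1`: 7.6 nM
- compound 3 `C[C@@H](NC1CCN(CCCc2c[nH]c3ccc(-n4cnnc4)cc23)CC1)c1ccccc1`: 13 nM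

Compound 3 gives the highest number of the three in this assay, though its gap to compound 2 is within the scatter; only compound 1 sits clearly lower. Compound 4 `CC(CO)(NC1CCN(CCCc2c[nH]c3ccc(-n4cnnc4)cc23)CC1)c1ccccc1` differs from compound 3 by 1-(hydroxymethyl)-1-phenylethyl in place of 1-phenylethyl on an amine nitrogen. Among the measured compounds shown here, no measured step copies this change. The closest one, a 1.7-fold higher number from compound 2 to compound 3 (0.23 log units; within the scatter), put a methyl onto the same chain carbon and barely moved the number. Adding the hydroxymethyl is expected to behave similarly, so only a small shift is expected, a 1.7-fold higher number from compound 3 to compound 4 (0.23 log units; within the scatter). Compound 4 is therefore estimated at 22 nM, within a range of 8 nM to 60 nM.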

Compound 4, half-maximal effective concentration: 3.4 nM
Compound 4: the middle estimate sits 6.5-fold (0.81 log units) above what was measured, outside the stated range (below it).
By their numbers in this assay, from the lowest: compounds 4 and 1 (each within the scatter of the next); then compounds 2 and 3 (each within the scatter of the next).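

In this assay the chain carbon on the amine nitrogen proves sensitive to substitution, as 1-(hydroxymethyl)-1-phenylethyl in place of 1-phenylethyl gives a 3.8-fold lower number from compound 3 to compound 4 (0.58 log units; beyond the scatter) and so moves the number beyond the scatter. The same group gives a 2.2-fold lower number from compound 2 to compound 4 (0.35 log units; beyond the scatter) and also a 1.0-fold lower number from compound 1 to compound 4 (0.01 log units; within the scatter) and thereby matches a quite different amine substituent within the scatter. Nothing available explains this shift.

On these data alone, it remains open whether the oxygen matters or the added carbon alone, which a second methyl, a methoxymethyl or an aminomethyl group on that carbon could separate.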